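The source may hold more compounds than are shown below. What is called first, only, known or untested is meant among the compounds shown, and "the series" means these compounds.

Three compounds have been measured in an ADME assay on cells (Macrophage, Mus musculus) for cytotoxicity, read by resazurin assay, with a stated time of 3 days; on this read-out higher numbers stand for weaker inhibition and lower numbers for stronger inhibition:

- compound 1 `O=C(Nc1cccc(Br)c1)c1cc(Cl)ccc1O`: 5700 nM
- compound 2 `N#Cc1cccc(NC(=O)c2cc(Cl)ccc2O)c1`: 10000 nM
- compound 3 `O=C(O)c1cccc(NC(=O)c2cc(Cl)ccc2O)c1`: > 60000 nM (a limit, not a number)

The values of compound 1 and compound 2 lie within the scatter of each other, as shown by a 1.8-fold higher number from compound 1 to compound 2 (0.24 log units; within the scatter). Compound 3 has no exact value and stands at the limit of > 60000 nM in this assay, at which 1 of the 3 values shown sits.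

Compound 4 `CCOC(=O)c1cccc(NC(=O)c2cc(Cl)ccc2O)c1` differs from compound 3 in one place: ethyl in place of hydrogen on an oxygen next to a carbonyl group. This is ethyl in place of hydrogen on an oxygen next to a carbonyl group, which turns carboxy into ethoxycarbonyl.

Going by the values given here, no measured step makes this same change, so the evidence is indirect. Two steps lead to the carboxy group and both are beyond the scatter: an at least 10-fold higher number from compound 1 to compound 3 (1.02 log units; beyond the scatter) and an at least 6.0-fold higher number from compound 2 to compound 3 (0.77 log units; beyond the scatter). Among these three compounds, only the one carrying carboxy reaches the limit, while the bromo and cyano compounds give close values. With carboxy gone, compound 4 is expected to return toward that pair, so a sizeable move to a lower number is expected in this assay. The expected step is an at least 6.6-fold lower number from compound 3 to compound 4 (0.82 log units; beyond the scatter). Compound 4 is estimated at 9000 nM, with an expected range from 3500 nM to 25000 nM.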

Compound 4, half-maximal inhibitory concentration: 17000 nM
Estimate against measurement, compound 4: 1.9-fold (0.28 log units) below, and the stated range covers the measured number.
By their numbers in this assay, from the lowest: compounds 1, 2 and 4 (each within the scatter of the next, the first and the last beyond it). At a limit, above all of these: compound 3.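

In this assay, ethyl in place of hydrogen on an oxygen next to a carbonyl group gives an at least 3.5-fold lower number from compound 3 to compound 4 (0.54 log units; beyond the scatter), so among these compounds the reading at the limit belongs to carboxy and does not carry over to ethoxycarbonyl, even though both groups hold a carbonyl at this place. Ethoxycarbonyl cannot be told apart from cyano, with a 1.7-fold higher number from compound 2 to compound 4 (0.23 log units; within the scatter), yet it does separate from bromo, with a 3.0-fold higher number from compound 1 to compound 4 (0.47 log units; beyond the scatter), which gives this place a spread among its uncharged-by-count replacements that the close bromo and cyano pair alone did not show. The value of compound 3 remains a limit and not a number, so the step from it gives only a minimum size: the limit of > 60000 nM in this assay, at which 1 of the 4 values shown sits.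

The compounds shown leave open whether a longer chain on the oxygen, or a methyl group in place of the ethyl, would keep the number near that of compound 4. They also leave open how a primary amide or an amine would read at this same place on the shared core.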